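Amine Chain Change on a Chlorinated Benzimidazole Core

This account rests on a few compounds, and the source may have more. Where it says the series, first, only, none or still open, it means among the compounds named here.

Measured compounds:
compound 1 `CCN(CC)CCn1c(N)c(-c2nc3ccccc3n2C)c2nc(C#N)c(C#N)nc21`: > 50000 nM
compound 2 `CN(C)CCCn1c(N)c(-c2nc3ccccc3n2C)c2nc(C#N)c(C#N)nc21`: 3560 nM
compound 3 `CCN(CC)CCn1c(N)c(-c2nc3cc(Cl)ccc3[nH]2)c2nc(C#N)c(C#N)nc21`: > 50000 nM

In a functional assay on K562 cells (Homo sapiens) for antiproliferative activity, read by MTT assay, with a stated time of 48 h (on this read-out higher numbers stand for weaker inhibition and lower numbers for stronger inhibition), compound 1 gives > 50000 nM, which is a limit of the assay. Compound 2 gives 3560 nM in this assay. The change between them is (dimethylamino)methyl in place of diethylamino on a saturated chain carbon, two bonds along the chain from an aromatic nitrogen, and it made an at least 14-fold lower number from compound 1 to compound 2 (1.14 log units; beyond the scatter). Compound 3 gives > 50000 nM in this assay, again a limit. The cores of compound 1 and compound 3 differ by 5-chloro-1H-benzimidazol-2-yl in place of 1-methyl-1H-benzimidazol-2-yl on an aromatic carbon, giving a step that the two limits leave unreadable from compound 1 to compound 3.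

Compound 4 `CN(C)CCCn1c(N)c(-c2nc3cc(Cl)ccc3[nH]2)c2nc(C#N)c(C#N)nc21` carries the core of compound 3 with the change ((dimethylamino)methyl in place of diethylamino on a saturated chain carbon, two bonds along the chain from an aromatic nitrogen), the same change seen from compound 1 to compound 2. For compound 4 a step of an at least 5.0-fold lower number from compound 3 to compound 4 (0.69 log units; beyond the scatter) is expected in this assay, because an at least 14-fold lower number from compound 1 to compound 2 (1.14 log units; beyond the scatter) shows the change working on the other core, while the limit of > 50000 nM in this assay, at which 2 of the 3 values shown sit, leaves the true position of compound 3 open. Compound 4 is estimated at 10000 nM in this assay, within 2500 nM to 50000 nM.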

Compound 4, half-maximal inhibitory concentration: 10700 nM
The estimate for compound 4 lay 1.1-fold (0.03 log units) below the measured number; the range from low to high includes it.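

In this assay, 3-(dimethylamino)propyl in place of 2-(diethylamino)ethyl also lowered the number on the core of compound 3, with an at least 4.6-fold lower number from compound 3 to compound 4 (0.66 log units; beyond the scatter), so the change points the same way on both cores shown: the same change on two cores in this assay, an at least 14-fold lower number (1.14 log units; beyond the scatter) from compound 1 to compound 2 and an at least 4.6-fold lower number (0.66 log units; beyond the scatter) from compound 3 to compound 4; the limit leaves it open whether they differ Its size on either core is known only as a minimum, and the data do not show whether the change works equally on the two cores or would carry over to any further core: the limit of > 50000 nM in this assay, at which 2 of the 4 values shown sit. With the 3-(dimethylamino)propyl chain in place, the core swap gives a 3.0-fold higher number from compound 2 to compound 4 (0.48 log units; beyond the scatter), whereas the same swap on the 2-(diethylamino)ethyl chain cannot be read.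

The compounds shown alter the chain length and the groups on the amine nitrogen together, leaving open which of the two accounts for the step; a 2-(dimethylamino)ethyl or 3-(diethylamino)propyl chain would separate them. The core swap likewise moves the chlorine and the methyl on the benzimidazole nitrogen at once, and a benzimidazole carrying both groups or neither would separate those.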